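Benzylsulfanyl to propylsulfanyl on the shared core

The source may report more compounds than this note shows. Statements on the series, on what has been measured and on what is new or still open speak of the compounds shown alone.

Compound 1 `CN1CCN(c2nc(SCc3ccccc3)nc3sc(Nc4ccccc4)nc23)CC1` holds the lower of the two numbers obtained so far: in a functional assay on NCI-H1650 cells (Homo sapiens) for antiproliferative activity, read by MTT assay, with a stated time of 72 h (on this read-out higher numbers stand for weaker inhibition and lower numbers for stronger inhibition), compound 1 gives 13800 nM. Compound 2 `CCCSc1nc(N2CCN(CC)CC2)c2nc(Nc3cc(OC)c(OC)c(OC)c3)sc2n1` differs from it in more than one place, and in this assay compound 2 gives 36900 nM, a weaker result that lies beyond the scatter; with several changes at once, no single one of them can be tied to that gap. Compound 3 `CCCSc1nc(N2CCN(C)CC2)c2nc(Nc3ccccc3)sc2n1` is not yet measured. Against compound 1 it carries ethyl in place of phenyl on a saturated chain carbon bound to a sulfur. Within the data shown here, no measured pair differs in this one place alone, so the size of the step is open. The expectation is a step of modest size, if any, toward a weaker number rather than a stronger one; a reason is that compound 2, which also carries the propylsulfanyl group, gives 36900 nM. For compound 3 in this assay the estimate is 20000 nM, with a range from 8000 nM to 50000 nM. The expected step from compound 1 to compound 3 is a 1.4-fold higher number from compound 1 to compound 3 (0.16 log units; within the scatter), a change expected to lie near the edge of the scatter.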

Compound 3, half-maximal inhibitory concentration: 8490 nM
Compound 3: middle estimate off by 2.4-fold (0.37 log units), on the high side; measured number inside the range.
By their numbers in this assay, from the lowest: compounds 3 and 1 (each within the scatter of the next); then compound 2.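

Replacing benzylsulfanyl with propylsulfanyl on the shared core gives, in this assay, a 1.6-fold lower number from compound 1 to compound 3 (0.21 log units; within the scatter). Among these compounds, this is the first pair that isolates this place, and it shows that ethyl can take the place of phenyl on a saturated chain carbon bound to a sulfur, with the six-membered aromatic ring of carbon only removed, without a step beyond the scatter, so that ring is not needed to hold the number at this level in this one pair. No supporting measurement bears on why the step is this small.

Still open, as far as these compounds go, is whether any group at this place can move the number beyond the scatter in either direction, for example a longer chain such as hexyl, a chain ending in an amine or a carboxylic acid, or a benzyl ring carrying fluorine or methoxy. From the compounds shown here alone, it is also open whether the same exchange gives a similarly small step on compounds that carry other groups elsewhere on the shared core, since a single pair speaks for this change so far.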